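Methylsulfonyl for Chloro: Expected Effect on Cell Growth Inhibition

The source may report more compounds than this note shows. Statements on the series, on what has been measured and on what is new or still open speak of the compounds shown alone.

Measured so far:
compound 1 `CS(=O)(=O)c1ccc(C(=O)Nc2ccc(Cl)c(-c3nnc4c(Cl)cccn34)c2)cc1` gives > 100000 nM in a functional assay on A549 cells (Homo sapiens) for antiproliferative activity, read by MTT assay, with a stated time of 72 h; a higher number here means a weaker inhibitor, a lower number a stronger inhibitor
compound 2 `O=C(Nc1ccc(Cl)c(-c2nnc3c(Cl)cccn23)c1)c1ccc(Cl)cc1Cl` gives 61300 nM in this assay

Among the compounds with values here, compound 2 holds the only plain number here. For compound 1 the value is a limit of the assay, not a number. Compound 3 `CS(=O)(=O)c1ccc(C(=O)Nc2ccc(Cl)c(-c3nnc4c(Cl)cccn34)c2)c(Cl)c1` differs from compound 2 by methylsulfonyl in place of chloro on an aromatic carbon. Within the data shown here, the single measured step, an at least 1.6-fold lower number from compound 1 to compound 2 (0.21 log units; that floor lies within the scatter), bears on this change in reverse: compound 3 carries the methylsulfonyl group also found in compound 1, for which only a limit was read (the limit of > 100000 nM in this assay, at which 1 of the 2 values shown sits). A rise in the number is therefore expected, a 1.8-fold higher number from compound 2 to compound 3 (0.25 log units; within the scatter), with a fair chance that only a limit is read again. Compound 3 is estimated at 110000 nM, between 40000 nM and 300000 nM.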

Compound 3, half-maximal inhibitory concentration: > 100000 nM
Compound 3: a limit, no number (the forecaster's own chance of this, stated with the estimate: 50%); the middle value lies beyond the limit too.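

In this assay, methylsulfonyl in place of chloro on this aromatic carbon gives an at least 1.6-fold higher number from compound 2 to compound 3 (0.21 log units; that floor lies within the scatter), so this change is not yet shown to matter beyond the scatter. The step between compound 1 and compound 3, which adds chloro, cannot be read, so chloro shows no readable gain while methylsulfonyl is present. Both compounds carrying methylsulfonyl now end at the same limit: the limit of > 100000 nM in this assay, at which 2 of the 3 values shown sit.

Going by these compounds, how far compound 1 and compound 3 lie past that limit remains open. So does whether an amine or a carboxylic acid on this carbon would give a plain number.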